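Swapping the Halogenated Phenyl Ring in a Cytotoxicity Series

The source may hold more compounds than are shown below. What is called first, only, known or untested is meant among the compounds shown, and "the series" means these compounds.

compound 1 `Cc1cc(C(=O)c2ccccc2)ccc1OCC(=O)Nc1nc(-c2ccccc2)cs1` — 22300 nM
compound 2 `Cc1ccc(C(=O)c2ccc(OCC(=O)Nc3nc(-c4ccccc4)cs3)c(C)c2)cc1` — 28400 nM
compound 3 `Cc1cc(C(=O)c2ccc(F)cc2)ccc1OCC(=O)Nc1nc(-c2ccccc2)cs1` — 35200 nM

Of the compounds shown here, three have been measured in a functional assay on Ehrlich cells (Mus musculus) for cytotoxicity, read by trypan blue exclusion, with a stated time of 48 h; on this read-out higher numbers stand for weaker inhibition and lower numbers for stronger inhibition. Compound 3 gives the highest of the three numbers, yet its distance to the other two is small: a 1.2-fold higher number from compound 2 to compound 3 (0.09 log units; within the scatter) and a 1.6-fold higher number from compound 1 to compound 3 (0.20 log units; within the scatter) both lie within the scatter, so no order among the three can be claimed. The remaining step, a 1.3-fold higher number from compound 1 to compound 2 (0.11 log units; within the scatter), is likewise within the scatter.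

Compound 4 `Cc1cc(C(=O)c2cccc(Br)c2)ccc1OCC(=O)Nc1nc(-c2ccccc2)cs1` is not yet measured. It differs from compound 3 in one place: 3-bromophenyl in place of 4-fluorophenyl on a carbonyl carbon. Among the measured compounds shown here, the steps that bear on this change are the two that alter the same phenyl ring, the fluoro-for-hydrogen step from compound 1 to compound 3 and the fluoro-for-methyl step from compound 2 to compound 3; both were within the scatter. For the measured compounds named here, no measured step introduces bromine or a 3-substituted phenyl, so nothing in the data points to a direction. Compound 4 is therefore expected to show no step beyond the scatter, a 1.2-fold lower number from compound 3 to compound 4 (0.07 log units; within the scatter). The estimate for compound 4 is 30000 nM, with a range from 12000 nM to 75000 nM.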

Compound 4, half-maximal inhibitory concentration: 24300 nM
The estimate for compound 4 lay 1.2-fold (0.09 log units) above the measured number; the range from low to high includes it.
By their numbers in this assay, from the lowest: compounds 1, 4, 2 and 3 (each within the scatter of the next).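

Among the compounds shown here, with compound 4, the phenyl ring on the carbonyl carbon now carries a bromine, and in this assay this still produces no step that stands out from the scatter, whichever neighbour it is read against (a 1.4-fold lower number from compound 3 to compound 4 (0.16 log units; within the scatter); a 1.2-fold lower number from compound 2 to compound 4 (0.07 log units; within the scatter); a 1.1-fold higher number from compound 1 to compound 4 (0.04 log units; within the scatter)). The position has thus taken 3-bromophenyl as well as phenyl, 4-methylphenyl and 4-fluorophenyl without any step beyond the scatter, which extends the earlier flat picture to a different halogen at a different place on this ring, though only for these four compounds. No supporting measurement is available to account for how closely these numbers sit together.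

Since the change to compound 4 alters both the halogen and its place on the ring, the compounds shown cannot separate the two, and they do not tell whether either one matters on its own. They also leave open whether a quite different group on this phenyl ring, such as an amine or a carboxylic acid, would give a step beyond the scatter.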